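A few compounds are considered here, and "the series" means these few. Any claim that something is new, unique, unknown or untested is made for them only; others in the source may bear on it.

In a functional assay on MDA-MB-231 cells (Homo sapiens) for cytotoxicity, read by MTT assay, with a stated time of 24 h (on this read-out higher numbers stand for weaker inhibition and lower numbers for stronger inhibition), compound 1 (`FC(F)(F)Oc1cccc(-c2nc3cccnc3n2C2CCCC2)c1`) gives 262 nM as a plain number. Compound 2 (`c1ccc(Oc2ccc(-c3nc4cccnc4n3C3CCCC3)cc2)cc1`) has > 10000 nM as a limit and not as a number. Compound 3 (`O=C(O)c1ccc(-c2nc3cccnc3n2C2CCCC2)cc1`) gives 600 nM and so holds the higher of the two actual numbers, a gap from compound 1 that lies beyond the scatter. Compound 4 (`NC(=O)c1ccc(-c2nc3cccnc3n2C2CCCC2)cc1`) has not been measured and differs from compound 3 in one place: amino in place of hydroxy on a carbonyl carbon (amino in place of hydroxy on a carbonyl carbon, or carboxy to carbamoyl). Among the compounds with values here, only one measured step bears on this part of the molecule: an at least 16-fold lower number from compound 2 to compound 3 (1.22 log units; beyond the scatter) (carboxy in place of phenoxy on an aromatic carbon), which is large and beyond the scatter. That step shows that the group carried here can matter in this assay, but it starts from a limit and exchanges a different group. Within the data shown here, no measured step exchanges hydroxy for amino on a carbonyl carbon, so compound 3 with 600 nM remains the best anchor. No change clearly beyond the scatter is therefore expected, with a slight lean towards a higher number. The expected change is a 1.3-fold higher number from compound 3 to compound 4 (0.12 log units; within the scatter) and remains modest. For compound 4 the estimate is 800 nM with an expected range from 200 nM to 3500 nM.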

Compound 4, half-maximal inhibitory concentration: 8000 nM
Compound 4: the middle estimate sits 10-fold (1.00 log units) below what was measured, and the stated range ends below it.
By their numbers in this assay, from the lowest: compound 1; then compound 3; then compound 4. At a limit, above all of these: compound 2.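

In this assay, the carbonyl carbon proves sensitive to a very small exchange: with amino in place of hydroxy, the step is a 13-fold higher number from compound 3 to compound 4 (1.12 log units; beyond the scatter) and is large. Within the data shown here, the earlier compounds showed only that exchanging a whole group on an aromatic carbon could matter, whereas here one heavy atom changes, while the count of hydrogen-bond donors and acceptors and the absence of net charge stay the same in the leaving and entering groups. The carbamoyl group also gains little that can be read against phenoxy, with an at least 1.2-fold lower number from compound 2 to compound 4 (0.09 log units; that floor lies within the scatter), so the amide gives no clear separation from compound 2, whose value is a limit and not a number: the limit of > 10000 nM in this assay, at which 1 of the 4 values shown sits.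

The compounds shown leave open whether the higher number follows from the loss of the hydroxy or from the arrival of the amino, which a methyl ester on the same carbonyl carbon would help to separate. They also leave open how a nitrile or a hydroxymethyl group would stand against compound 3 with its 600 nM.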